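Trimming the Sulfonamide Arm: From Compound 3 to Compound 4

The source may report more compounds than this note shows. Statements on the series, on what has been measured and on what is new or still open speak of the compounds shown alone.

Among the three measured compounds, compound 3 `CCCCc1ccc(CN(C)S(C)(=O)=O)c(=O)n1Cc1ccc(-c2ccccc2-c2nn[nH]n2)cc1` gives the lowest number in a functional assay (aorta) for antagonist activity, with Oryctolagus cuniculus as the target (on this read-out lower numbers stand for stronger inhibition and higher numbers for weaker inhibition), at 0.2 nM. Compound 2 `CCCCc1ccc(CN(C(C)C)S(C)(=O)=O)c(=O)n1Cc1ccc(-c2ccccc2-c2nn[nH]n2)cc1` gives 0.9 nM and compound 1 `CCCCc1ccc(CN(Cc2ccccc2)S(C)(=O)=O)c(=O)n1Cc1ccc(-c2ccccc2-c2nn[nH]n2)cc1` gives 2 nM. The measured steps of a 2.2-fold lower number from compound 1 to compound 2 (0.35 log units; beyond the scatter), a 10-fold lower number from compound 1 to compound 3 (1.00 log units; beyond the scatter) and a 4.5-fold lower number from compound 2 to compound 3 (0.65 log units; beyond the scatter) all ran toward lower numbers as the group on the sulfonamide nitrogen was made smaller. Compound 4 `CCCCc1ccc(C)c(=O)n1Cc1ccc(-c2ccccc2-c2nn[nH]n2)cc1` goes further, with the change (hydrogen in place of methyl(methylsulfonyl)amino on a saturated chain carbon bound to an aromatic carbon). This removes the whole group rather than shrinking one substituent, so no measured step matches it closely; the shown steps point toward lower numbers, yet the change here is larger than any of them. For compound 4 a modest step toward a higher number, a 5.0-fold higher number from compound 3 to compound 4 (0.70 log units; beyond the scatter), is expected, with an estimate of 1 nM in this assay and a range from 0.15 nM to 8 nM.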

Compound 4, half-maximal inhibitory concentration: 7 nM
The estimate for compound 4 lay 7.0-fold (0.85 log units) below the measured number; the measured number falls inside the stated range.
By their numbers in this assay, from the lowest: compound 3; then compound 2; then compound 1; then compound 4.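

In this assay, removing the whole group gave a 35-fold higher number from compound 3 to compound 4 (1.54 log units; beyond the scatter), alongside a 7.8-fold higher number from compound 2 to compound 4 (0.89 log units; beyond the scatter) and a 3.5-fold higher number from compound 1 to compound 4 (0.54 log units; beyond the scatter). The sulfonamide arm at this position therefore goes with lower numbers whichever of the three substituents it carries, and even the benzyl of compound 1 leaves it ahead of compound 4, so size on the nitrogen is not the whole story. No data shown here explain this difference.

From the compounds shown here alone, it remains open which part of the removed group matters: whether a plain amine, an acetamide or a carboxylic acid on that carbon would keep the lower numbers.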